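Chloro to Amino at the Second Carbon of the Core

The source may report more compounds than this note shows. Statements on the series, on what has been measured and on what is new or still open speak of the compounds shown alone.

Of the compounds shown here, three have so far been tested in a functional assay on HeLa cells (Homo sapiens) for inhibition; a lower number here means a stronger inhibitor, a higher number a weaker inhibitor. Compound 1 `CC(=O)OC(C)n1cnc2c(Cl)nc(N)nc21` gives only a limit in this assay, namely > 500000 nM. Compound 3 `CC(O)n1cnc2c(Cl)nc(I)nc21` likewise gives only a limit in this assay, namely > 500000 nM. Among the measured compounds shown here, compound 2 `CC(=O)OC(C)n1cnc2c(Cl)nc(I)nc21` is the single compound with a real number, giving 5130 nM in this assay, while the other two values sit at the limit of > 500000 nM in this assay, at which 2 of the 3 values shown sit. Two measured steps lead to and from it: an at least 97-fold lower number from compound 1 to compound 2 (1.98 log units; beyond the scatter), and an at least 97-fold higher number from compound 2 to compound 3 (1.98 log units; beyond the scatter).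

Compound 4 `CC(=O)OC(C)n1cnc2c(N)nc(I)nc21` is the next candidate. It differs from compound 2 by amino in place of chloro on an aromatic carbon. Neither measured step changes this carbon, so the evidence is indirect. Still, the step of an at least 97-fold lower number from compound 1 to compound 2 (1.98 log units; beyond the scatter) shows that an amino group elsewhere on the same core went together with a limit, which makes a weaker inhibitor the more likely outcome here. Compound 4 is therefore estimated at 30000 nM in this assay, with a range from 3000 nM to 500000 nM. That estimate corresponds to an expected step of a 5.8-fold higher number from compound 2 to compound 4 (0.77 log units; beyond the scatter).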

Compound 4, half-maximal inhibitory concentration: > 500000 nM
Compound 4: a limit, no number; the forecaster's own chance of this, stated with the estimate: 25%; at least 16-fold (1.22 log units) between middle value and limit.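

In this assay, the carbon carrying chloro now has a direct reading of its own: amino in place of chloro gives an at least 97-fold higher number from compound 2 to compound 4 (1.98 log units; beyond the scatter), and this step is a minimum size, since compound 4 gives a limit rather than a number. Earlier, only the iodo carbon and the acetyl group had been changed, so it now appears that compound 2 loses its measurable value when amino replaces either halogen. Compound 2 therefore remains the only compound with a real number, and the others share one limit: the limit of > 500000 nM in this assay, at which 3 of the 4 values shown sit.

As far as these compounds go, it remains open whether a different group on this carbon, such as fluoro, methyl or methoxy, would keep a measurable value. A smaller amine, such as methylamino, is equally untested by the compounds shown here.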